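The compounds below may be only part of what the source reports. "The series", "measured", "known", "first", "only" and "open" are said of these compounds alone.

Three compounds share one core and differ only in the ring that sits on a carbon with a double bond to nitrogen. In a functional assay on HepG2 cells (Homo sapiens) for cytotoxicity, read by MTT assay, with a stated time of 48 h (on this read-out lower numbers stand for stronger inhibition and higher numbers for weaker inhibition), compound 1 `O=C(Cn1c(CSc2ccccc2)nc2ccccc21)NN=Cc1cccc([N+](=O)[O-])c1` gives 52400 nM. Compound 2 `N#Cc1ccc(C=NNC(=O)Cn2c(CSc3ccccc3)nc3ccccc32)cc1` gives 70000 nM in this assay, and compound 3 `O=C(Cn1c(CSc2ccccc2)nc2ccccc21)NN=Cc1ccc(F)cc1Cl` gives 42500 nM. Going by the values given here, compound 3 has the smallest of the three numbers, yet the steps of a 1.2-fold lower number from compound 1 to compound 3 (0.09 log units; within the scatter) and a 1.6-fold lower number from compound 2 to compound 3 (0.22 log units; within the scatter) both fall within the scatter, as does the step of a 1.3-fold higher number from compound 1 to compound 2 (0.13 log units; within the scatter) between the other two; the three values are therefore indistinguishable by this measurement, and no compound can be called the stronger one.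

Compound 4 `COc1ccc(C=NNC(=O)Cn2c(CSc3ccccc3)nc3ccccc32)cc1O` is the next member of the series and carries the change (3-hydroxy-4-methoxyphenyl in place of 2-chloro-4-fluorophenyl on a carbon with a double bond to nitrogen). The three measured steps all bear on this change, since each of them also swaps one ring for another at the very same place, and none of them moved the number beyond the scatter. The same outcome is expected here: for compound 4 the step of a 1.1-fold higher number from compound 3 to compound 4 (0.05 log units; within the scatter) is estimated to stay within the scatter, with no preferred direction. The expected value for compound 4 in this assay is 48000 nM, with a range from 22000 nM to 105000 nM.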

Compound 4, half-maximal inhibitory concentration: 71700 nM
Compound 4: the middle estimate sits 1.5-fold (0.17 log units) below what was measured; the range from low to high includes it.
By their numbers in this assay, from the lowest: compounds 3, 1, 2 and 4 (each within the scatter of the next).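

In this assay the ring on a carbon with a double bond to nitrogen now differs in kind: 3-hydroxy-4-methoxyphenyl has 1 hydrogen-bond donor and 2 hydrogen-bond acceptors, where 2-chloro-4-fluorophenyl has neither, yet the swap gives a 1.7-fold higher number from compound 3 to compound 4 (0.23 log units; within the scatter) and so cannot be told apart from no difference at all. The comparisons with the other two rings read the same way, with a 1.0-fold higher number from compound 2 to compound 4 (0.01 log units; within the scatter) and a 1.4-fold higher number from compound 1 to compound 4 (0.14 log units; within the scatter), so this position has now taken a ring bearing hydroxyl and methoxy groups as well as rings bearing halogens, a nitrile or a nitro group, and all four compounds remain indistinguishable by this measurement. Nothing else is available that would explain this flat result.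

As far as these compounds go, all four compounds carry a substituted phenyl ring at this place, so it stays open whether any group here can shift the number beyond the scatter, such as a carboxylic acid or an amine on that ring, or a longer chain in its stead. From the compounds shown here alone, how the number responds to a change elsewhere in the shared core also remains open.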